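Hydroxyacyl prolinamide series: phenyl for methylcyclopropylmethyl

A few compounds are considered here, and "the series" means these few. Any claim that something is new, unique, unknown or untested is made for them only; others in the source may bear on it.

Measured so far:
- compound 1 `CC1(C[C@@H](O)C(=O)N2[C@@H]3C[C@@H]3C[C@H]2C(=O)NCc2cc(Cl)ccc2-n2cnnn2)CC1`: 1300 nM
- compound 2 `O=C(NCc1cc(Cl)ccc1-n1cnnn1)[C@@H]1CCNN1C(=O)[C@H](O)c1ccccc1`: 930 nM
- compound 3 `CCCC[C@@H](O)C(=O)N1C[C@H]2C[C@H]2[C@H]1C(=O)NCc1cc(Cl)ccc1-n1cnnn1`: 750 nM

All three were run in a functional assay on a cell-free system (plasma, Homo sapiens), with a stated time of 3 min; on this read-out lower numbers stand for stronger inhibition and higher numbers for weaker inhibition. Compound 1 gives the highest number of the three, but its gap to compound 2 and its gap to compound 3 both lie within the usual scatter of this assay, so the three compounds are not separated on the numbers shown.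

Compound 4 `O=C(NCc1cc(Cl)ccc1-n1cnnn1)[C@@H]1C[C@H]2C[C@H]2N1C(=O)[C@H](O)c1ccccc1` has not been measured. It differs from compound 1 in one place: phenyl in place of (1-methylcyclopropyl)methyl on a saturated chain carbon bound to a carbonyl carbon and an oxygen on a saturated carbon. Compound 4 keeps the core of compound 1 and carries the phenyl that compound 2 carries on its own core.

Since compound 2, with phenyl in this position, gives 930 nM and, with butyl on the core that compound 4 shares with compound 1, compound 3 gives 750 nM, the step of a 1.6-fold lower number from compound 1 to compound 4 (0.21 log units; within the scatter) is expected to be small, towards a slightly lower number, and not clearly beyond the scatter. Compound 4 is therefore estimated at 800 nM, with a range from 350 nM to 1800 nM in this assay.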

Compound 4, half-maximal inhibitory concentration: 680 nM
Estimate against measurement, compound 4: 1.2-fold (0.07 log units) above; the range from low to high includes it.
By their numbers in this assay, from the lowest: compounds 4, 3, 2 and 1 (each within the scatter of the next).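

In this assay, phenyl in place of (1-methylcyclopropyl)methyl on a saturated chain carbon bound to a carbonyl carbon and an oxygen on a saturated carbon gives a 1.9-fold lower number from compound 1 to compound 4 (0.28 log units; within the scatter), so on the shared core the numbers do not separate an aromatic carbon ring from a three-membered non-aromatic one at this position. For the compounds shown here, the earlier compounds offered no step differing in one place, which makes this the only direct reading of the position so far. No measurement shown bears on why the two groups read alike.

Going by these compounds, whether an amine or a carboxylic acid at this position would move the number beyond the scatter remains open. So does the effect of a longer chain or a chloro-substituted phenyl on the core of compound 1.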